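Compound 3 to compound 4: a ring exchanged

The source may hold more compounds than are shown below. What is called first, only, known or untested is meant among the compounds shown, and "the series" means these compounds.

Measured in an ADME assay on microsomes from liver (Homo sapiens) for metabolic stability; a higher number here means faster removal of the compound, a lower number slower removal:
- Compound 1 `Cc1cccc([C@H](C)NC(=O)Cn2nnc3ccccc3c2=O)c1`: 11 mL/min/kg
- Compound 2 `C[C@H](NC(=O)Cn1nnc2ccccc2c1=O)c1ccc(F)cc1`: 31 mL/min/kg
- Compound 3 `Cc1ccc([C@H](C)NC(=O)Cn2nnc3ccccc3c2=O)cn1`: < 9.9 mL/min/kg, a limit of the assay

Compound 3 stands at the limit of < 9.9 mL/min/kg in this assay, at which 1 of the 3 values shown sits. This is a limit and not a number.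

Compound 4 `C[C@H](NC(=O)Cn1nnc2ccccc2c1=O)c1nccs1` carries 1,3-thiazol-2-yl in place of 6-methylpyridin-3-yl on a saturated chain carbon bound to an amide-type nitrogen and a saturated chain carbon.

Going by the values given here, no measured step makes this exact exchange, but three others change the ring at the same place. Two lie beyond the scatter: a 2.8-fold higher number from compound 1 to compound 2 (0.45 log units; beyond the scatter) and an at least 3.1-fold lower number from compound 2 to compound 3 (0.49 log units; beyond the scatter). The third, an at least 1.1-fold lower number from compound 1 to compound 3 (0.04 log units; that floor lies within the scatter), has a floor within the scatter. A modest rise in this assay is therefore expected, with compound 2 at 31 mL/min/kg as the highest value seen so far. The expected change is an at least 1.4-fold higher number from compound 3 to compound 4 (0.15 log units; that floor lies within the scatter). For compound 4 the estimate is 14 mL/min/kg, with an expected range from 9 mL/min/kg to 28 mL/min/kg.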

Compound 4, clearance: < 9.9 mL/min/kg
Compound 4 was reported as a limit; the forecaster's own chance of this, stated with the estimate: 30%; at least 1.4-fold (0.15 log units) between middle value and limit.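

In this assay, the result shows that this place tolerates a five-membered ring as well as a six-membered one: 1,3-thiazol-2-yl gives an at least 3.1-fold lower number from compound 2 to compound 4 (0.49 log units; beyond the scatter), the same clear separation from 4-fluorophenyl that 6-methylpyridin-3-yl showed. Against 3-methylphenyl the separation is not established, with an at least 1.1-fold lower number from compound 1 to compound 4 (0.04 log units; that floor lies within the scatter), so compound 1 remains a possible member of the same low group. Compound 3 and compound 4 cannot be ordered, and the step between them cannot be read: the limit of < 9.9 mL/min/kg in this assay, at which 2 of the 4 values shown sit.

Going by these compounds, how far compound 3 and compound 4 actually lie past that limit remains unknown. Also open, on these data alone, is whether another ring with hetero atoms at this place, such as 1,3-oxazol-2-yl or pyrimidin-5-yl, would give an equally low number.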